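The source may report more compounds than this note shows. Statements on the series, on what has been measured and on what is new or still open speak of the compounds shown alone.

Measured in a functional assay on MCF7 cells (Homo sapiens) for antiproliferative activity, read by MTT assay, with a stated time of 72 h; on this read-out higher numbers stand for weaker inhibition and lower numbers for stronger inhibition:
compound 1 `O=C1NC(=S)S/C1=C\C1=Cc2cc(Br)ccc2OC1` gives 40400 nM.
compound 2 `CC1Oc2ccc(Br)cc2C=C1/C=C1\SC(=O)NC1=O` gives 67600 nM.
compound 3 `CC1Oc2ccc(Br)cc2C=C1/C=C1\SC(=O)N(C)C1=O` gives only a limit, > 50000 nM.

Within the data shown here, compound 3 thus stands at the edge of this assay with no number of its own; it is the one value that sits at the limit of > 50000 nM in this assay, at which 1 of the 3 values shown sits. Compounds 1 and 2 both lie in the weak range. The step that the limit leaves unreadable from compound 2 to compound 3 stays unreadable, so the effect of the methyl on the ring nitrogen is not known. Compound 4 `CCN1C(=O)S/C(=C\C2=Cc3cc(Br)ccc3OC2C)C1=O` differs from compound 3 by methyl in place of hydrogen on a saturated chain carbon bound to an amide-type nitrogen in a ring. Among the measured compounds shown here, no measured step bears on this change directly; the one neighbouring step is unreadable, and compounds 1 and 2 show only weak values. Compound 4 is therefore expected to remain near the limit, with a step that the limit leaves unreadable from compound 3 to compound 4 not beyond the scatter. Compound 4 is estimated at 80000 nM, between 30000 nM and 250000 nM, most likely reported again only as a limit.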

Compound 4, half-maximal inhibitory concentration: > 100000 nM
Compound 4 was reported as a limit (the forecaster's own chance of this, stated with the estimate: 70%); middle value at least 1.2-fold (0.09 log units) from the limit.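

In this assay compound 4 gives only a limit, > 100000 nM. Unlike the methyl step, the step to ethyl on the nitrogen gives a readable floor, an at least 1.4-fold higher number from compound 2 to compound 4 (0.17 log units; that floor lies within the scatter), so a real loss is not established. The steps that end in or run between limits cannot be read, which leaves methyl and ethyl at this place unordered.

The compounds shown leave open whether a longer chain, or a chain ending in an amine or a carboxylic acid, on this nitrogen would give a number rather than a limit in this assay. On these data alone, the true size of the step to ethyl also stays open.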